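This account rests on a few compounds, and the source may have more. Where it says the series, first, only, none or still open, it means among the compounds named here.

Compound 1, `CCCCN1CCC(C(=O)Nc2cc(Cl)c(N)cc2OC)CC1`: > 10 mg/kg
Compound 2, `COc1cc(N)c(Cl)cc1NC(=O)C1CCN(Cc2ccccc2)CC1`: 0.5 mg/kg
Compound 3, `CCCCCN1CCC(C(=O)Nc2cc(Cl)c(N)cc2OC)CC1`: > 10 mg/kg

In a functional assay on the whole organism for antagonist activity, with Mus musculus as the target (on this read-out higher numbers stand for an effect only at larger amounts of compound and lower numbers for an effect already at smaller amounts), compound 1 gives > 10 mg/kg, which is a limit of the assay and not a number. Compound 1 thus stands at the limit of > 10 mg/kg in this assay, at which 2 of the 3 values shown sit. Compound 3 gives > 10 mg/kg, also a limit. Compound 2 gives 0.5 mg/kg. Compound 4, `COc1cc(N)c(Cl)cc1NC(=O)C1CCN(CC2CCC2)CC1`, is not yet measured and differs from compound 1 by cyclobutyl in place of propyl on a saturated chain carbon bound to an amine nitrogen in a ring. The step that bears on this change is an at least 20-fold lower number from compound 1 to compound 2 (1.30 log units; beyond the scatter), where a ring likewise took the place of the propyl. The step that the two limits leave unreadable from compound 1 to compound 3 gives nothing readable. Since cyclobutyl is a saturated ring rather than phenyl, a smaller move in the same direction is expected. Compound 4 is estimated at 4 mg/kg, with a range from 1 mg/kg to 15 mg/kg. The expected step is an at least 2.5-fold lower number from compound 1 to compound 4 (0.39 log units; beyond the scatter).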

Compound 4, dose for half-maximal effect: > 10 mg/kg
Compound 4: only a limit was reported; the forecaster's own chance of this, stated with the estimate: 45%; middle value at least 2.5-fold (0.39 log units) away from the limit.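

In this assay, a ring at this place is not enough to give a low number, for cyclobutyl gives an at least 20-fold higher number from compound 2 to compound 4 (1.30 log units; beyond the scatter). Compound 4 gives > 10 mg/kg, which is a limit of the assay and not a number, and its steps to compound 1 and compound 3 join limit to limit and cannot be read. Of the four groups shown at this place, only phenyl gives a measured number, and the limit now holds for most of the series: the limit of > 10 mg/kg in this assay, at which 3 of the 4 values shown sit.

On these data alone, how far compound 1, compound 3 and compound 4 actually differ remains open. So does how a cyclohexyl, a pyridyl or a phenylethyl group on the amine nitrogen in the ring would read.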